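Replacing the thiazolyl on the amide nitrogen with propyl

The compounds below may be only part of what the source reports. "The series", "measured", "known", "first", "only" and "open" are said of these compounds alone.

Measured compounds:
- compound 1, `Cc1ccc(OCC(=O)N(Cc2cccs2)C2COC2)cc1`: 23000 nM
- compound 2, `C=CCN(Cc1cccs1)C(=O)COc1ccc(C)cc1`: 20 nM
- compound 3, `Cc1ccc(OCC(=O)N(Cc2cccs2)c2nccs2)cc1`: 2240 nM

All three were tested in an assay on HEK293 cells for agonist activity at transient receptor potential cation channel subfamily M member 8 (Homo sapiens), read by fluorescence and calcium flux, with a stated time of 15 min; a higher number here means that more compound is needed for the effect, a lower number that less compound is needed. Compound 3 stands second highest of the three numbers: compound 1 lies a 10-fold lower number from compound 1 to compound 3 (1.01 log units; beyond the scatter) away, while compound 2 sits much lower, the step being a 110-fold higher number from compound 2 to compound 3 (2.05 log units; beyond the scatter). Compound 4, `CCCN(Cc1cccs1)C(=O)COc1ccc(C)cc1`, is not yet measured. Its change from compound 3 is propyl in place of 1,3-thiazol-2-yl on an amide-type nitrogen.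

Within the data shown here, two measured steps bear on this. The step of a 110-fold higher number from compound 2 to compound 3 (2.05 log units; beyond the scatter) shows what the 1,3-thiazol-2-yl costs against an allyl, and the step of a 1200-fold lower number from compound 1 to compound 2 (3.06 log units; beyond the scatter) shows that an allyl on this nitrogen gives by far the lowest number of the set. Propyl is a saturated chain of the same length as allyl, so the expectation is that compound 4 reverses most of the loss seen in compound 3, with a step of a 56-fold lower number from compound 3 to compound 4 (1.75 log units; beyond the scatter) expected in this assay. Compound 4 is therefore estimated at 40 nM, with a range from 10 nM to 200 nM.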

Compound 4, half-maximal effective concentration: 40 nM
Estimate against measurement, compound 4: no gap at the digits printed, and the stated range covers the measured number.
By their numbers in this assay, from the lowest: compounds 2 and 4 (each within the scatter of the next); then compound 3; then compound 1.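

In this assay the step of a 2.0-fold higher number from compound 2 to compound 4 (0.30 log units; within the scatter) shows that allyl and propyl on this amide-type nitrogen cannot be told apart, so the vinyl end of the allyl chain is not needed for a low number. Against propyl, the two ring groups stay far off, with a 56-fold lower number from compound 3 to compound 4 (1.75 log units; beyond the scatter) for 1,3-thiazol-2-yl and a 580-fold lower number from compound 1 to compound 4 (2.76 log units; beyond the scatter) for oxetan-3-yl as the group replaced. Among these four compounds, then, the low numbers belong to both open chains and not to allyl alone, and compounds 1 and 3, which carry rings at this place, go with neither.

The compounds shown leave open whether a longer chain such as butyl, a branched isopropyl or a chain ending in an amine would keep the number low. They also leave open whether a small carbocycle such as cyclopropyl would match the open chains. No measurement shown here gives a reason for these differences.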